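Moving the Amide on a Chloropyrimidine Core

A few compounds are considered here, and "the series" means these few. Any claim that something is new, unique, unknown or untested is made for them only; others in the source may bear on it.

Compound 1 `O=C(Nc1cc(C(F)(F)F)cc(C(F)(F)F)c1)c1cnc(Cl)nc1C(F)(F)C(F)(F)F` gives 800 nM in an assay on Jurkat cells for activation of nuclear factor NF-kappa-B complex (Homo sapiens); on this read-out higher numbers stand for weaker inhibition and lower numbers for stronger inhibition. Compound 2 `O=C(Nc1cc(C(F)(F)F)cc(C(F)(F)F)c1)c1cc(Cl)nc(Cl)n1` gives > 10000 nM in this assay, which is a limit and not a number.

Compound 2 thus sits at the limit of > 10000 nM in this assay, at which 1 of the 2 values shown sits, and its standing among the two values shown is only a bound. Compound 3 `Cc1nc(Cl)ncc1C(=O)Nc1cc(C(F)(F)F)cc(C(F)(F)F)c1` differs from compound 2 by 2-chloro-4-methylpyrimidin-5-yl in place of 2,6-dichloropyrimidin-4-yl on a carbonyl carbon. For the measured compounds named here, no measured step covers this change, so its size is uncertain; the step of an at least 3.3-fold lower number from compound 2 to compound 3 (0.52 log units; beyond the scatter) is expected to run toward stronger inhibition and beyond the usual scatter. Compound 3 is expected near 3000 nM, within a range from 700 nM to 12000 nM.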

Compound 3, half-maximal inhibitory concentration: 50 nM
Compound 3: the middle estimate sits 60-fold (1.78 log units) above what was measured, and the stated range ends above it.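

The exchange of 2,6-dichloropyrimidin-4-yl for 2-chloro-4-methylpyrimidin-5-yl on a carbonyl carbon brings an at least 200-fold lower number from compound 2 to compound 3 (2.30 log units; beyond the scatter) in this assay, so the read-out depends strongly on this group. Compound 2 enters that step only as a limit: the limit of > 10000 nM in this assay, at which 1 of the 3 values shown sits. Methyl in place of 1,1,2,2,2-pentafluoroethyl on an aromatic carbon brings a 16-fold lower number from compound 1 to compound 3 (1.20 log units; beyond the scatter), so the pentafluoroethyl group is not required for inhibition in this series.

As far as these compounds go, whether an ethyl or methoxy group on that aromatic carbon would keep this gain remains open. So does the effect of an amine in place of the chlorine of compound 3.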